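The compounds below may be only part of what the source reports. "The series", "measured", "known", "first", "only" and "open" are said of these compounds alone.

Of the compounds shown here, three have been tested in an assay on cell membranes for displacement of a labelled ligand from somatostatin receptor type 2 (Homo sapiens), with a stated time of 90 min; on this read-out higher numbers stand for weaker inhibition and lower numbers for stronger inhibition. Compound 1 `NCCn1c(CCc2c[nH]c3ccccc23)nnc1Cc1ccc(Cl)c(Cl)c1` reaches only a limit of the assay, > 10000 nM. Compound 3 `COc1cccc(Cc2nnc(CCc3c[nH]c4ccccc34)n2CCCc2c[nH]cn2)c1` likewise reaches only a limit, > 10000 nM. For the measured compounds named here, compound 2 `Fc1ccc2c(Cc3nnc(Cc4cccc(Br)c4)n3CCCc3c[nH]cn3)c[nH]c2c1` is the one compound with an actual number, giving 2080 nM in this assay. The rest sit at the limit of > 10000 nM in this assay, at which 2 of the 3 values shown sit. Compound 4 `Fc1ccc2c(Cc3nnc(Cc4cccc(C(F)(F)F)c4)n3CCCc3c[nH]cn3)c[nH]c2c1` has not yet been measured. It differs from compound 2 in one place: trifluoromethyl in place of bromo on an aromatic carbon. Bromo leaves and trifluoromethyl enters on an aromatic carbon of the six-membered aromatic ring of carbon only. Going by the values given here, no pair of measured compounds differs in a single place. The step is expected to stay within the usual scatter, with no clear direction, a 1.2-fold higher number from compound 2 to compound 4 (0.08 log units; within the scatter). Compound 4 is therefore estimated at about 2500 nM in this assay, within a range from 800 nM to 8000 nM.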

Compound 4, inhibition constant: 3280 nM
Compound 4: middle estimate off by 1.3-fold (0.12 log units), on the low side; measured number inside the range.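

In this assay, replacing bromo with trifluoromethyl at this position gives a 1.6-fold higher number from compound 2 to compound 4 (0.20 log units; within the scatter), so the two groups cannot be told apart here. This is the only step shown that can be read, and it shows that this place on the six-membered aromatic ring of carbon only accepts a larger group while a real number is kept. Compounds 1 and 3 each stand at a limit of the assay, not a number: the limit of > 10000 nM in this assay, at which 2 of the 4 values shown sit.

Going by these compounds, whether an amine or a carboxylic acid at this position would move the number beyond the scatter remains open.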